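Swapping a Chloromethyl for a Chloropyridinyl Group

A few compounds are considered here, and "the series" means these few. Any claim that something is new, unique, unknown or untested is made for them only; others in the source may bear on it.

Of the compounds shown here, three have so far been measured in an ADME assay on HEK293 cells (Homo sapiens) for inhibition, with a stated time of 72 h; on this read-out lower numbers stand for an effect already at smaller amounts and higher numbers for an effect only at larger amounts of compound. Compound 1 `O=C(Nc1ccc(Cl)cc1)c1cc([N+](=O)[O-])ccc1Cl` reaches only a limit of this assay and gives > 25000 nM there. For the measured compounds named here, compound 2 `O=C(CCl)Nc1cccc(-c2nc3ccccc3s2)c1` gives 10000 nM in this assay and is the only compound with a full number. Compound 3 `O=C(Nc1cccc(-c2nc3ccccc3s2)c1)c1cccnc1Cl` likewise stops at a limit of this assay and gives > 25000 nM there. Compound 2 thus stands alone as the definite figure, while the other two values sit at the limit of > 25000 nM in this assay, at which 2 of the 3 values shown sit.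

Compound 4 `O=C(Nc1cccc(-c2nc3ccccc3s2)c1)c1ccnc(Cl)c1` has not yet been measured. It differs from compound 2 in one place: 2-chloropyridin-4-yl in place of chloromethyl on a carbonyl carbon. Going by the values given here, one measured step bears on this change. Replacing the same chloromethyl with a 2-chloropyridin-3-yl produced an at least 2.5-fold higher number from compound 2 to compound 3 (0.39 log units; beyond the scatter), so a closely related aryl amide moved out to the limit of this assay. A similar move is expected for the new aryl amide, and the expected step is a 3.0-fold higher number from compound 2 to compound 4 (0.48 log units; beyond the scatter) in size. Compound 4 is therefore estimated at about 30000 nM in this assay, with an expected range from 8000 nM to 100000 nM and a fair chance of only a limit being reported.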

Compound 4, half-maximal effective concentration: > 25000 nM
Compound 4: no number, only a limit; the forecaster's own chance of this, stated with the estimate: 60%; the middle value is on the limit's open side.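

In this assay, the 2-chloropyridin-4-yl group repeats what the 2-chloropyridin-3-yl group did, giving an at least 2.5-fold higher number from compound 2 to compound 4 (0.39 log units; beyond the scatter). The shift away from compound 2 is therefore no longer tied to a single aryl amide, and among the compounds that share this core, only the chloromethyl compound keeps a full number: the limit of > 25000 nM in this assay, at which 3 of the 4 values shown sit. Compound 3 and compound 4 both stop at a limit, so the step between them cannot be read, and these data cannot separate the two chloropyridinyl groups.

From the compounds shown here alone, it remains open how far past the limit either compound lies. Going by these compounds, it is also open whether a plain phenyl ring, a pyridine without chlorine, or a simple methyl on the carbonyl carbon would stay near compound 2 or also reach the limit.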